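A few compounds are considered here, and "the series" means these few. Any claim that something is new, unique, unknown or untested is made for them only; others in the source may bear on it.

Compound 1 `O=C(/C=C/[C@H]1C[C@@H](O)[C@@H](O)C1)Nc1ccc(Cl)cc1` and compound 2 `COc1ccc(NC(=O)/C=C/[C@H]2C[C@@H](O)[C@@H](O)C2)cc1` share one core and differ only at one aromatic carbon. In an ADME assay on S2 cells (Drosophila melanogaster) for cytotoxicity, read by MTT assay (a lower number here means that less compound is needed, a higher number that more compound is needed for the effect), compound 1 gives a limit, > 180000 nM. In this assay compound 2 also gives only a limit, > 180000 nM. The step that the two limits leave unreadable from compound 1 to compound 2 cannot be sized, because the limit of > 180000 nM in this assay, at which 2 of the 2 values shown sit, holds both values. Compound 3 `CC(=O)c1ccc(NC(=O)/C=C/[C@H]2C[C@@H](O)[C@@H](O)C2)cc1` differs from compound 2 by acetyl in place of methoxy on an aromatic carbon. Among the measured compounds shown here, the one measured change at this aromatic carbon gave no readable size, so no shift beyond scatter is expected. Compound 3 is expected to stay at the limit, a step that the limit leaves unreadable from compound 2 to compound 3 in this assay. Compound 3 is estimated at 250000 nM, between 100000 nM and 700000 nM.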

Compound 3, half-maximal effective concentration: > 180000 nM
Compound 3: no number, only a limit (the forecaster's own chance of this, stated with the estimate: 85%); the middle value is on the limit's open side.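

No step can be read among compound 1, compound 2 and compound 3 in this assay, because all three stop at one limit: the limit of > 180000 nM in this assay, at which 3 of the 3 values shown sit.

The compounds shown leave open whether chloro, methoxy and acetyl differ at all in this assay.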